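The source may report more compounds than this note shows. Statements on the series, on what has been measured and on what is new or still open speak of the compounds shown alone.

In a physicochemical assay for lipophilicity (on this read-out higher numbers stand for higher lipophilicity and lower numbers for lower lipophilicity), three compounds sharing one core have been measured. Compound 1 `COC(=O)/C=C(C)/C=C/CC(C)CCCC(C)(C)OC` gives 5, compound 2 `CCC(C)OC(=O)/C=C(C)/C=C/CC(C)CCCC(C)(C)OC` gives 6.49, and compound 3 `COC(C)(C)CCCC(C)C/C=C/C(C)=C/C(=O)OCCC(C)C` gives 7.03, the highest of the three numbers. Compound 4 `C/C=C/COC(=O)/C=C(C)/C=C/CC(C)CCCC(C)(C)OC` has not yet been measured. The structural change to it is prop-1-en-1-yl in place of isobutyl on a saturated chain carbon bound to an oxygen next to a carbonyl group. Cut one bond further out, this reads isopentyl to but-2-en-1-yl.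

For the measured compounds named here, three measured steps bear on this change. Sec-butyl in place of methyl on an oxygen next to a carbonyl group gave a large rise, a number 1.49 log units higher from compound 1 to compound 2 (beyond the scatter). Isobutyl in place of hydrogen on the saturated chain carbon bound to that oxygen gave a larger rise, a number 2.03 log units higher from compound 1 to compound 3 (beyond the scatter). Isopentyl in place of sec-butyl gave a modest rise, a number 0.54 log units higher from compound 2 to compound 3 (beyond the scatter). The but-2-en-1-yl group looks closer to the sec-butyl of compound 2, at 6.49, than to isopentyl. A modest fall is therefore expected in this assay, estimated as a number 0.73 log units lower from compound 3 to compound 4 (beyond the scatter). The estimate for compound 4 is 6.3, with an expected range from 5.9 to 6.7.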

Compound 4, partition coefficient: 6.07
Estimate against measurement, compound 4: 0.23 log units above; low and high end bracket the measured number.
By their numbers in this assay, from the lowest: compound 1; then compound 4; then compound 2; then compound 3.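

In this assay this position now carries a chain with a double bond, and prop-1-en-1-yl in place of isobutyl on the saturated chain carbon bound to an oxygen next to a carbonyl group brings a modest fall (a number 0.96 log units lower from compound 3 to compound 4 (beyond the scatter)). But-2-en-1-yl also stands under sec-butyl on that oxygen (a number 0.42 log units lower from compound 2 to compound 4 (beyond the scatter)), so among the groups shown it ranks below both the isopentyl and the sec-butyl. It still stands clearly over the methyl of compound 1 (a number 1.07 log units higher from compound 1 to compound 4 (beyond the scatter)), so the number at this position is not set by the double bond alone.

No measured finding here explains these differences. The compounds shown leave open whether a straight butyl chain, which has no double bond and no branch, would read closer to compound 4 or to compound 2, and how an amine or a carboxylic acid at the end of this chain would read.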